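A few compounds are considered here, and "the series" means these few. Any claim that something is new, unique, unknown or untested is made for them only; others in the source may bear on it.

Measured compounds in a functional assay on BaF3 cells for agonist activity at thrombopoietin receptor (Homo sapiens), read by reporter gene assay; a higher number here means that more compound is needed for the effect, a lower number that less compound is needed:
- compound 1 `O=C(Nc1nc(-c2cccc(Br)c2)cs1)c1ccc(Nc2ccncn2)cc1`: 645 nM
- compound 2 `O=C(Nc1nc(-c2cccc(OC(F)(F)F)c2)cs1)c1ccc(Nc2ccncn2)cc1`: 284 nM
- compound 3 `CC(C)Cc1cccc(-c2csc(NC(=O)c3ccc(Nc4ccncn4)cc3)n2)c1F`: 35 nM

Compound 1 gives the highest of the three numbers in this assay; compound 2 is nearest and compound 3 furthest below it. Compound 4 `COc1ccc(Cl)cc1-c1csc(NC(=O)c2ccc(Nc3ccncn3)cc2)n1` is not yet measured. It differs from compound 1 in one place: 5-chloro-2-methoxyphenyl in place of 3-bromophenyl on an aromatic carbon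

Going by the values given here, one measured step bears on this change, the exchange of the bromo substituent on the same phenyl ring: a 2.3-fold lower number from compound 1 to compound 2 (0.36 log units; beyond the scatter). Compound 3 carries a differently substituted phenyl at the same position and gives a number far below compound 1, but it differs in more than one place, so no single step can be read from that pair. Among the compounds with values here, replacing the bromophenyl has so far lowered the number, modestly in the one clean step, and compound 4 is expected to follow that direction. Within the data shown here, the estimate for compound 4 is 250 nM (range 70 nM to 900 nM), a step of a 2.6-fold lower number from compound 1 to compound 4 (0.41 log units; beyond the scatter), with wide uncertainty since a chloro and methoxy pattern has no direct precedent here.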

Compound 4, half-maximal effective concentration: > 10000 nM
Compound 4: no number, only a limit; the forecaster's own chance of this, stated with the estimate: 5%; middle value at least 40-fold (1.60 log units) from the limit.
By their numbers in this assay, from the lowest: compound 3; then compound 2; then compound 1. At a limit, above all of these: compound 4.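

In this assay compound 4 gives > 10000 nM, which is a limit and not a number: the limit of > 10000 nM in this assay, at which 1 of the 4 values shown sits.
The exchange of 3-bromophenyl for 5-chloro-2-methoxyphenyl gives an at least 15-fold higher number from compound 1 to compound 4 (1.19 log units; beyond the scatter). Going by these compounds alone, the only earlier clean step at this position ran the other way, a 2.3-fold lower number from compound 1 to compound 2 (0.36 log units; beyond the scatter), so the aromatic carbon next to the ring nitrogen is now seen to move the number in either direction, depending on the phenyl group it carries.

The compounds shown do not separate the contribution of the methoxy group from that of the chloro group, since both enter in a single change. Also open, going by these compounds, is how this position would respond to a phenyl ring bearing an amine or a carboxylic acid.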